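The source may report more compounds than this note shows. Statements on the series, on what has been measured and on what is new or still open speak of the compounds shown alone.

In a functional assay on HCT-116 cells (Homo sapiens) for inhibition, read by MTT assay, with a stated time of 48 h (on this read-out higher numbers stand for weaker inhibition and lower numbers for stronger inhibition), compound 1 (`O=C(CCCCOc1no[n+]([O-])c1S(=O)(=O)c1ccccc1)NO`) gives 2180 nM, and compound 2 (`O=C(CCCCCCOc1no[n+]([O-])c1S(=O)(=O)c1ccccc1)NO`) gives 4690 nM, the higher of the two numbers. Compound 3 (`O=C(COCCOc1no[n+]([O-])c1S(=O)(=O)c1ccccc1)NO`) has not yet been measured. Its structural change from compound 2 is (hydroxycarbamoyl)methoxy in place of 4-(hydroxycarbamoyl)butyl on a saturated chain carbon, two bonds along the chain from an oxygen on an aromatic ring. Within the data shown here, only one measured step bears on this: a 2.2-fold higher number from compound 1 to compound 2 (0.33 log units; beyond the scatter), where the chain grew longer. Among the measured compounds shown here, no measured step tests the oxygen that the new group brings into the chain. With a shorter group, a modest drop of similar size is expected, a 1.9-fold lower number from compound 2 to compound 3 (0.27 log units; within the scatter). Compound 3 is estimated at 2500 nM, within a range of 1000 nM to 6000 nM.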

Compound 3, half-maximal inhibitory concentration: 13400 nM
Estimate against measurement, compound 3: 5.4-fold (0.73 log units) below; measured number above the stated range.
By their numbers in this assay, from the lowest: compound 1; then compound 2; then compound 3.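

In this assay, (hydroxycarbamoyl)methoxy in place of 4-(hydroxycarbamoyl)butyl gives a 2.9-fold higher number from compound 2 to compound 3 (0.46 log units; beyond the scatter), so a shorter group does not by itself bring a lower number at this position. Set against compound 1, whose chain has the same length but carries a carbon where compound 3 has an oxygen, the change gives a 6.1-fold higher number from compound 1 to compound 3 (0.79 log units; beyond the scatter), the largest step among these compounds. No measurement here explains this rise. From the compounds shown here alone, whether an amine nitrogen or a sulfur at that chain position would behave like the oxygen remains open, and so does a longer chain holding the same oxygen.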